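Vinyl to 4-methylphenyl exchange: three measured, one pending

This account rests on a few compounds, and the source may have more. Where it says the series, first, only, none or still open, it means among the compounds named here.

Measured compounds, with their half-maximal inhibitory concentration in a functional assay on A549 cells (Homo sapiens) for inhibition, read by sulforhodamine B assay, with a stated time of 48 h; a higher number here means a weaker inhibitor, a lower number a stronger inhibitor:
Compound 1 `COc1ccc(C(O)(Cc2ccc(C)cc2)c2cccc3ccccc23)c(OC)c1OC` gives 18700 nM.
Compound 2 `C=CCC(O)(c1ccc(OC)c(OC)c1OC)c1cccc2ccccc12` gives 10700 nM.
Compound 3 `C=CCOC(c1ccc(OC)c(OC)c1OC)c1cccc2ccccc12` gives 9710 nM.

All three numbers sit close together; the pairwise gaps are within the scatter, so none of the three can be called stronger or weaker than the others. For the measured compounds named here, the one step measured in this assay, a 1.7-fold higher number from compound 2 to compound 1 (0.24 log units; within the scatter), is the change (4-methylphenyl in place of vinyl on a saturated chain carbon, two bonds along the chain from two aromatic carbons and an oxygen on a saturated carbon).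

Compound 3 and compound 2 are built from the same atoms joined differently; the difference between the two cores is not broken down here.

Compound 4 `COc1ccc(C(OCc2ccc(C)cc2)c2cccc3ccccc23)c(OC)c1OC` is not yet measured. It stands to compound 3 as compound 1 stands to compound 2: 4-methylphenyl in place of vinyl on a saturated chain carbon bound to an oxygen on a saturated carbon. The place differs in words, on a saturated chain carbon bound to an oxygen on a saturated carbon rather than two bonds along the chain from two aromatic carbons and an oxygen on a saturated carbon, so it is the same kind of change, not the same. The expected step in this assay, a 1.5-fold higher number from compound 3 to compound 4 (0.19 log units; within the scatter), is taken to resemble the earlier one, because a 1.7-fold higher number from compound 2 to compound 1 (0.24 log units; within the scatter) was within the scatter. Compound 4 is accordingly estimated at 15000 nM, with a range from 7000 nM to 35000 nM.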

Compound 4, half-maximal inhibitory concentration: 15700 nM
The estimate for compound 4 lay 1.0-fold (0.02 log units) below the measured number; the measured number falls inside the stated range.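

In this assay, putting 4-methylphenyl in place of vinyl gives a 1.6-fold higher number from compound 3 to compound 4 (0.21 log units; within the scatter), so on this core the exchange cannot be called a change in strength. Set beside the earlier step, the exchange reads alike on the two cores: the same change on two cores in this assay, a 1.7-fold higher number (0.24 log units; within the scatter) from compound 2 to compound 1 and a 1.6-fold higher number (0.21 log units; within the scatter) from compound 3 to compound 4, 1.1-fold (0.03 log units) apart, within the scatter of two such steps

This shows that the exchange stays within the scatter on the core of compound 1 and on the core of compound 4, and that a step read on one of these cores held on the other. It does not show that the exchange would stay this small on any further core, and with steps this small, the agreement says little about how well a larger effect would carry over.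

The compounds shown leave open whether another group in the same place, such as an amine, a carboxylic acid or a longer chain, would move the number beyond the scatter. They also leave open whether changes elsewhere on the shared core would do so.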